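A few compounds are considered here, and "the series" means these few. Any claim that something is new, unique, unknown or untested is made for them only; others in the source may bear on it.

Measured compounds in this series:

Compound 1 `O=C(OC1(C(=O)Nc2ccc([N+](=O)[O-])cc2)CCCCC1)c1ccc(Br)cc1` — in a functional assay on MCF7 cells (Homo sapiens) for inhibition, read by MTT assay, with a stated time of 72 h (on this read-out lower numbers stand for stronger inhibition and higher numbers for weaker inhibition), compound 1 gives 237 nM.
Compound 2 `O=C(OC1(C(=O)Nc2ccc([N+](=O)[O-])cc2)CCCCC1)c1ccccc1I` — in this assay compound 2 gives 619 nM.
Compound 3 `O=C(/C=C/c1ccccc1)OC1(C(=O)Nc2ccc([N+](=O)[O-])cc2)CCCCC1` — in this assay compound 3 gives 57.6 nM.

All three share the core of compound 1 and differ only in the group on the carbonyl carbon of the ester. On these numbers compound 3 stands lowest: a 4.1-fold lower number from compound 1 to compound 3 (0.61 log units; beyond the scatter), and an 11-fold lower number from compound 2 to compound 3 (1.03 log units; beyond the scatter). Between the two halogenated phenyl esters the gap is smaller, a 2.6-fold higher number from compound 1 to compound 2 (0.42 log units; beyond the scatter).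

Compound 4 `O=COC1(C(=O)Nc2ccc([N+](=O)[O-])cc2)CCCCC1` is the unmeasured member. The change from compound 3 is hydrogen in place of 2-phenylethenyl on a carbonyl carbon, so the ester is reduced to a formate. Going by the values given here, no measured step removes the group on the carbonyl carbon altogether; the steps that bear on it are the two that swap this group, and they show the identity of the group moves this assay by modest to large amounts, the largest being an 11-fold lower number from compound 2 to compound 3 (1.03 log units; beyond the scatter). Taking away the whole group is a bigger structural change than any of those swaps, so a step well beyond the scatter toward a higher number is expected for compound 4. The estimate for compound 4 in this assay is 900 nM, within 180 nM to 5000 nM. This estimate corresponds to an expected 16-fold higher number from compound 3 to compound 4 (1.19 log units; beyond the scatter).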

Compound 4, half-maximal inhibitory concentration: 35.4 nM
Compound 4: middle estimate off by 25-fold (1.41 log units), on the high side; measured number below the stated range.
By their numbers in this assay, from the lowest: compounds 4 and 3 (each within the scatter of the next); then compound 1; then compound 2.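

In this assay, the group on the carbonyl carbon turns out not to be required for the lowest numbers in the series: hydrogen in place of 2-phenylethenyl, which removes an aromatic ring and a double bond, leaves the read-out within the scatter (a 1.6-fold lower number from compound 3 to compound 4 (0.21 log units; within the scatter)). Hydrogen also stands clearly apart from both halogenated phenyl groups, with 2-iodophenyl (a 17-fold lower number from compound 2 to compound 4 (1.24 log units; beyond the scatter)) and with 4-bromophenyl (a 6.7-fold lower number from compound 1 to compound 4 (0.83 log units; beyond the scatter)), so among these four compounds the higher numbers belong to the two halogenated phenyl esters, while hydrogen and 2-phenylethenyl cannot be told apart. Nothing available on these compounds accounts for why the position accepts hydrogen and 2-phenylethenyl alike yet gives higher numbers with the halogenated phenyl groups.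

The compounds shown leave open whether a methyl group, a longer alkyl chain or an unsubstituted phenyl group on the carbonyl carbon would sit with hydrogen and 2-phenylethenyl or with the halogenated phenyl groups. They also leave open what happens with a free hydroxyl group in place of the whole ester on the shared core.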